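Nitrobenzoxadiazole thioether esters: amide variation and glutathione S-transferase P

The compounds below may be only part of what the source reports. "The series", "measured", "known", "first", "only" and "open" are said of these compounds alone.

Measured compounds:
compound 1 `Cc1ccc(NC(=O)CCC(=O)OCCCCCCSc2ccc([N+](=O)[O-])c3nonc23)cc1`, 6800 nM
compound 2 `COc1ccc(NC(=O)CCC(=O)OCCCCCCSc2ccc([N+](=O)[O-])c3nonc23)cc1OC`, 6470 nM
compound 3 `CN(C)CCCNC(=O)CCC(=O)OCCCCCCSc1ccc([N+](=O)[O-])c2nonc12`, 160 nM

In an assay on isolated protein for inhibition of glutathione S-transferase P (Homo sapiens), with a stated time of 10 min (on this read-out higher numbers stand for weaker inhibition and lower numbers for stronger inhibition), compound 3 gives the lowest number of the three, with compound 2 its nearest neighbour and compound 1 the furthest; both gaps lie beyond the scatter. The two aryl amides sit close together, as a 1.1-fold lower number from compound 1 to compound 2 (0.02 log units; within the scatter) shows, whereas the change of the amide nitrogen substituent in a 43-fold lower number from compound 1 to compound 3 (1.63 log units; beyond the scatter) and a 40-fold lower number from compound 2 to compound 3 (1.61 log units; beyond the scatter) moves the number a long way.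

Compound 4 `O=C(CCC(=O)N1CCOCC1)OCCCCCCSc1ccc([N+](=O)[O-])c2nonc12` keeps the shared core and alters only the amide end: morpholin-4-yl in place of (3-(dimethylamino)propyl)amino on a carbonyl carbon. For the measured compounds named here, the steps that bear on this are the two large ones leading to compound 3, which show that the group on this carbonyl governs most of the spread seen so far. Compound 4 gives up the group that produced those gains, yet does not return to an aryl amide, so a step upward in this assay beyond the scatter is expected, smaller than a full reversal of the earlier gains. For compound 4 the expected result is 2000 nM, within 500 nM to 8000 nM, meaning an estimated 13-fold higher number from compound 3 to compound 4 (1.10 log units; beyond the scatter).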

Compound 4, half-maximal inhibitory concentration: 330 nM
Compound 4: middle estimate off by 6.1-fold (0.78 log units), on the high side; the measured number lies below the stated range.
By their numbers in this assay, from the lowest: compound 3; then compound 4; then compounds 2 and 1 (each within the scatter of the next).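

In this assay, morpholin-4-yl in place of (3-(dimethylamino)propyl)amino on a carbonyl carbon costs little, with a 2.1-fold higher number from compound 3 to compound 4 (0.31 log units; beyond the scatter), a modest step that lies just beyond the scatter. Measured against the aryl amides, the same position gives a 20-fold lower number from compound 2 to compound 4 (1.29 log units; beyond the scatter) and a 21-fold lower number from compound 1 to compound 4 (1.31 log units; beyond the scatter), so among these four compounds a low number at this carbonyl is not tied to the (3-(dimethylamino)propyl)amino group and is also reached with a six-membered non-aromatic ring. The amide hydrogen is not required for most of this gain either: the entering morpholin-4-yl has 0 hydrogen-bond donors against 1 in the leaving group, yet compound 4 stays far closer to compound 3 than to either aryl amide.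

The compounds shown leave open which feature separates compound 3 and compound 4 from the aryl amides, and how a piperidin-1-yl, a 4-methylpiperazin-1-yl or a carboxylic acid at this carbonyl would compare. Nothing here gives a measured basis for explaining either the small gap or the large ones.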